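Swapping the aryl group on the piperazine of compound 3

The compounds below may be only part of what the source reports. "The series", "measured", "known", "first", "only" and "open" are said of these compounds alone.

Compound 1, `CC/C=C/c1c(C)nn(CCCN2CCN(c3ccc(C)cc3)CC2)c(=O)c1N`, in a functional assay on the whole organism (Abdomen, strain Swiss) for inhibition, with Mus musculus as the target, with stated times of 30 min, 10 min and 5 min, at a dose of 10 mg/kg by the oral route (a lower number here means a weaker effect, a higher number a stronger effect of the compound at the dose given), gives 5%.
Compound 2, `C=Cc1c(C)nn(CCCN2CCN(c3ccc(F)cc3)CC2)c(=O)c1N`, gives 0%.
Compound 3, `C=Cc1c(C)nn(CCCCN2CCN(c3ccc(C)cc3)CC2)c(=O)c1N`, gives 3%.

All three numbers are low, and each lies within the usual scatter of the other two, so compound 3 cannot be told apart from compound 1 or compound 2 on these measurements. Compound 4, `C=Cc1c(C)nn(CCCCN2CCN(c3ccccc3OCC)CC2)c(=O)c1N`, has not yet been measured. It differs from compound 3 in one place: 2-ethoxyphenyl in place of 4-methylphenyl on an amine nitrogen in a ring. Within the data shown here, no pair of measured compounds shows what such a change does here, so no shift beyond the scatter is expected for the step of a number 2 percentage points higher from compound 3 to compound 4 (within the scatter). Compound 4 is therefore estimated at 5%, with a range from 0% to 15%.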

Compound 4, a percentage reported as inhibition, in the whole organism at one dose (the size of the read-out at that dose, not a potency): "not active" (no number reported)
The entry for compound 4 holds no number, and the estimate cannot be compared.
By their numbers in this assay, from the lowest: compounds 2, 3 and 1 (each within the scatter of the next).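

Among these compounds, compound 4 is reported as not active, with no number, so no step from compound 3 to compound 4 can be read. What 2-ethoxyphenyl does in place of 4-methylphenyl stays open, and no evidence here explains this result.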